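Acylsulfonamide series: aryl on the sulfonyl

A few compounds are considered here, and "the series" means these few. Any claim that something is new, unique, unknown or untested is made for them only; others in the source may bear on it.

Measured compounds:
- compound 1, `COc1cc(C(=O)NS(=O)(=O)c2c(C)cccc2Cl)ccc1Cn1ccc2ccc(NC(=O)CC3CCCC3)cc21`, 8.8
- compound 2, `CCCCC(CC)C(=O)Nc1ccc2cnn(Cc3ccc(-c4nn[nH]n4)cc3OC)c2c1`, 7.1

Compound 1 gives the highest of the two numbers in a functional assay (trachea) for antagonist activity, with Cavia porcellus as the target; on this read-out higher numbers stand for higher potency (the scale is a negative logarithm) and lower numbers for lower potency. Compound 2 sits lower, and the gap between the two values is beyond the usual scatter. Compound 2 is built on a different frame, so nothing of it can be read as a single change against compound 1; its value stands on its own.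

Compound 3, `COc1cc(C(=O)NS(=O)(=O)c2ccccn2)ccc1Cn1ccc2ccc(NC(=O)CC3CCCC3)cc21`, has not been measured in this assay. It keeps the core of compound 1 and differs in one place: pyridin-2-yl in place of 2-chloro-6-methylphenyl on a sulfonyl sulfur. Within the data shown here, no measured pair in the set shows what this exchange does, so the expectation rests on the value of compound 1 alone.

Going by these compounds, the expected step from compound 1 is a modest loss, a number 0.50 log units lower from compound 1 to compound 3 (beyond the scatter), since the group that leaves is the one present in the most potent compound measured and the one that enters is untested here. Compound 3 is therefore estimated at 8.3, with a range of 7.6 to 8.9 in this assay.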

Compound 3, negative logarithm of the antagonist equilibrium constant: 8.9
Compound 3: middle estimate off by 0.60 log units, on the low side; measured number inside the range.
By their numbers in this assay, from the lowest: compound 2; then compounds 1 and 3 (each within the scatter of the next).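

In this assay, pyridin-2-yl in place of 2-chloro-6-methylphenyl on a sulfonyl sulfur gives a number 0.10 log units higher from compound 1 to compound 3 (within the scatter). Among these compounds, this is the first reading at this position, and it shows that the 2-chloro-6-methylphenyl group is not needed to hold the number on the core of compound 1: an aromatic ring without the chlorine and the methyl, carrying one ring nitrogen and with 6 heavy atoms instead of 8, serves equally well within the scatter. No measurement on these compounds bears on what lies behind this outcome.

The single exchange changes several things at once, so the compounds shown leave open whether the loss of chlorine and methyl and the entry of the ring nitrogen each matter on their own, a question that plain phenyl on the same sulfur would address. They also leave open whether an aromatic ring is required at this position at all, which a methyl or cyclopropyl group on the sulfonyl sulfur would test.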